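Acetyl to bromo on the aromatic carbon

The source may report more compounds than this note shows. Statements on the series, on what has been measured and on what is new or still open speak of the compounds shown alone.

Among the compounds with values here, compound 2 `CC(=O)c1ccc(-c2cn3ccnc3c(-c3ccc4ncn(C5CCCCC5)c4c3)n2)cc1` stands lowest of the two numbers so far: in a functional assay on SNB-19 cells (Homo sapiens) for inhibition, read by sulforhodamine B assay, with a stated time of 48 h, tested at 10 uM (a higher number here means more inhibition at the concentration tested (going by the name of the read-out), a lower number less inhibition), compound 2 gives 3.96%, while compound 1 `Fc1ccc(-c2cn3ccnc3c(-c3ccc4ncn(C5CCCCC5)c4c3)n2)cc1` gives 14.2%. Within the data shown here, the single measured step, a number 10.2 percentage points lower from compound 1 to compound 2 (beyond the scatter), is the only comparison in hand for this series. Compound 3 `Brc1ccc(-c2cn3ccnc3c(-c3ccc4ncn(C5CCCCC5)c4c3)n2)cc1` differs from compound 2 by bromo in place of acetyl on an aromatic carbon. This change removes the same acetyl that entered in the step from compound 1 to compound 2 and puts a halogen in its place, as compound 1 carries one, so that step bears on it in the reverse sense, and a rise of roughly its size is expected rather than no step beyond the scatter; bromo is not fluoro, so a full return is not assumed. Compound 3 is therefore expected to come to 12%, within a range of 0% to 30%, which means an expected step of a number 8 percentage points higher from compound 2 to compound 3 (within the scatter).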

Compound 3, a percentage reported as inhibition, at one concentration (the size of the read-out at that concentration, not a potency): 18.3%
For compound 3 the middle estimate is 6.3 percentage points below the measured one; low and high end bracket the measured number.
By their numbers in this assay, from the lowest: compound 2; then compounds 1 and 3 (each within the scatter of the next).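

Bromo in place of acetyl on the aromatic carbon gives a number 14.3 percentage points higher from compound 2 to compound 3 (beyond the scatter) in this assay and so runs opposite to a number 10.2 percentage points lower from compound 1 to compound 2 (beyond the scatter) where acetyl entered in place of fluoro. Fluoro and bromo are not told apart, with a number 4.1 percentage points higher from compound 1 to compound 3 (within the scatter) as their step, so at this place the two halogens read alike and acetyl alone stands apart among the three compounds. Nothing measured here gives a reason for the separation of acetyl from the halogens.

From the compounds shown here alone, whether the lower number belongs to acetyl alone or also to other groups on this aromatic carbon stays open; an amine, a carboxylic acid or a methoxy group there would bear on it. All three compounds share the rest of the core, so this reading holds for this one place only.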